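Pyridin-4-yl Replacing the Trifluoromethylphenyl Arm on a Pyrazole Core

The source may hold more compounds than are shown below. What is called first, only, known or untested is meant among the compounds shown, and "the series" means these compounds.

Measured so far:
compound 1 `Cc1nn(-c2nc(-c3ccc(Cl)c(Cl)c3)c(SC(C)C)s2)c(C(=O)O)c1-c1cccc(C(F)(F)F)c1`, 22000 nM
compound 2 `Cc1nn(-c2nc(-c3ccc(Cl)c(Cl)c3)c(SC(C)C)s2)c(C(=O)O)c1-c1cc(C(F)(F)F)cc(C(F)(F)F)c1`, 1800 nM

In a functional assay on BJAB cells (Homo sapiens) for antiproliferative activity, with a stated time of 4 days (a higher number here means that more compound is needed for the effect, a lower number that less compound is needed), compound 1 stands highest of the two numbers. Its nearest neighbour is compound 2, and the step of a 12-fold lower number from compound 1 to compound 2 (1.09 log units; beyond the scatter) arises from a trifluoromethyl in place of hydrogen on an aromatic carbon. Compound 3 `Cc1nn(-c2nc(-c3ccc(Cl)c(Cl)c3)c(SC(C)C)s2)c(C(=O)O)c1-c1ccncc1` differs from compound 1 by pyridin-4-yl in place of 3-(trifluoromethyl)phenyl on an aromatic carbon. For the measured compounds named here, no measured step covers this exchange directly; the only step in hand shows that adding a trifluoromethyl lowered the number sharply, which makes a rise plausible here. For compound 3 a step of a 2.3-fold higher number from compound 1 to compound 3 (0.36 log units; beyond the scatter) is expected, giving an estimate of 50000 nM, within 15000 nM to 150000 nM.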

Compound 3, half-maximal effective concentration: 5900 nM
Beside the measured number, compound 3's estimate is 8.5-fold (0.93 log units) above it, outside the stated range (below it).
By their numbers in this assay, from the lowest: compound 2; then compound 3; then compound 1.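

In this assay the exchange of 3-(trifluoromethyl)phenyl for pyridin-4-yl gives a 3.7-fold lower number from compound 1 to compound 3 (0.57 log units; beyond the scatter) and so shows that this position does not depend on a trifluoromethyl group for a lower number. The earlier step changed only a substituent on the carbon ring, whereas this one shows that the ring itself can carry a nitrogen. Nothing measured here accounts for this step. Still open, as far as these compounds go, is whether pyridin-3-yl would give a similar step, and whether an amine or a methyl group on the pyridin-4-yl ring would move the number further.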